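This account rests on a few compounds, and the source may have more. Where it says the series, first, only, none or still open, it means among the compounds named here.

Measured so far in this series:
compound 1 `Nc1ccccc1NC(=O)c1ccc(CSC(=S)N2CCN(c3ccc(Cl)cc3)CC2)cc1`: 44.8%
compound 2 `Nc1ccccc1NC(=O)c1ccc(CSC(=S)N2CCN(c3ccc(F)cc3)CC2)cc1`: 64.5%
compound 3 `Nc1ccccc1NC(=O)c1ccc(CSC(=S)N2CCN(Cc3ccccc3)CC2)cc1`: 31.3%

In a functional assay on HeLa cells (Homo sapiens) for antiproliferative activity, read by CCK-8 assay, with a stated time of 72 h, tested at 8 uM (on this read-out higher numbers stand for a stronger effect at the one concentration tested and lower numbers for a weaker effect), compound 3 stands lowest of the three. One step into it is a number 13.5 percentage points lower from compound 1 to compound 3 (beyond the scatter), the other is a number 33.2 percentage points lower from compound 2 to compound 3 (beyond the scatter); both arise when benzyl replaces 4-chlorophenyl or 4-fluorophenyl on the amine nitrogen in the ring. Compound 4 `Nc1ccccc1NC(=O)c1ccc(CSC(=S)N2CCN(c3cnccn3)CC2)cc1` is not yet measured; it differs from compound 3 by pyrazin-2-yl in place of benzyl on an amine nitrogen in a ring. The two steps into compound 3 bear on it, both downward when benzyl enters, so putting an aromatic ring back on the amine nitrogen in the ring is expected to give an upward step, a number 15.7 percentage points higher from compound 3 to compound 4 (beyond the scatter). Going by the values given here, no measured compound carries a ring with hetero atoms there, so the size is uncertain. Compound 4 is estimated at 47%, range 28% to 66%.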

Compound 4, a percentage reported as inhibition, at one concentration (the size of the read-out at that concentration, not a potency): 76.9%
Beside the measured number, compound 4's estimate is 29.9 percentage points below it; measured number above the stated range.
By their numbers in this assay, from the lowest: compound 3; then compound 1; then compound 2; then compound 4.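

In this assay pyrazin-2-yl on the amine nitrogen in a ring gives a number 45.6 percentage points higher from compound 3 to compound 4 (beyond the scatter) and also passes both halogen-bearing phenyl groups, with a number 12.4 percentage points higher from compound 2 to compound 4 (beyond the scatter) and a number 32.1 percentage points higher from compound 1 to compound 4 (beyond the scatter) as the steps. The earlier compounds shown here, all with carbon-only rings here, therefore did not mark the top of this position, and a ring with hetero atoms now holds the highest number of the four. No measured evidence accounts for these steps.

Open, on these data alone, is whether a pyridin-2-yl or pyrimidin-2-yl ring would keep this gain. An unsubstituted phenyl would also separate the effect of the ring nitrogens from that of the halogens.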